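Replacing the anilino with hydroxy on the imine nitrogen

The source may report more compounds than this note shows. Statements on the series, on what has been measured and on what is new or still open speak of the compounds shown alone.

compound 1 `O=c1cc(/C=N\c2ccc(O)cc2)c2ccc(OCc3ccccc3)cc2o1`: 233000 nM
compound 2 `O=c1cc(/C=N\Nc2ccc([N+](=O)[O-])cc2)c2ccc(OCc3ccccc3)cc2o1`: the assay limit > 2000000 nM
compound 3 `O=c1cc(/C=N\Nc2ccccc2)c2ccc(OCc3ccccc3)cc2o1`: 455000 nM

Of the compounds shown here, three sharing one core have been tested in a functional assay, read by spectrophotometry, with a stated time of 1 h; on this read-out lower numbers stand for stronger inhibition and higher numbers for weaker inhibition. Compound 1 `O=c1cc(/C=N\c2ccc(O)cc2)c2ccc(OCc3ccccc3)cc2o1` gives 233000 nM. Compound 2 `O=c1cc(/C=N\Nc2ccc([N+](=O)[O-])cc2)c2ccc(OCc3ccccc3)cc2o1` sits at the limit of > 2000000 nM in this assay, at which 1 of the 3 values shown sits. Compound 3 `O=c1cc(/C=N\Nc2ccccc2)c2ccc(OCc3ccccc3)cc2o1` gives 455000 nM, the higher of the two numbers, although a 2.0-fold higher number from compound 1 to compound 3 (0.29 log units; within the scatter) stays within the scatter. By contrast, an at least 4.3-fold lower number from compound 2 to compound 3 (0.64 log units; beyond the scatter) lies beyond it.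

Compound 4 `O=c1cc(/C=N\O)c2ccc(OCc3ccccc3)cc2o1` has not yet been measured; it carries hydroxy in place of anilino on a double-bonded nitrogen. For the measured compounds named here, no measured step removes the aromatic ring from the double-bonded nitrogen. The nearest, a 2.0-fold higher number from compound 1 to compound 3 (0.29 log units; within the scatter), alters only a substituent on that ring, and an at least 4.3-fold lower number from compound 2 to compound 3 (0.64 log units; beyond the scatter) likewise changes a ring substituent. A step no larger than the scatter is therefore expected for a 1.0-fold lower number from compound 3 to compound 4 (0.00 log units; within the scatter). Compound 4 is expected to give about 450000 nM, between 150000 nM and 1400000 nM.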

Compound 4, half-maximal inhibitory concentration: > 2000000 nM
Compound 4: a limit, no number; the forecaster's own chance of this, stated with the estimate: 15%; middle value at least 4.4-fold (0.64 log units) away from the limit.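

In this assay the ring-free hydroxy on the double-bonded nitrogen brings an at least 4.3-fold higher number from compound 3 to compound 4 (0.64 log units; beyond the scatter) and also an at least 8.5-fold higher number from compound 1 to compound 4 (0.93 log units; beyond the scatter), so inhibition weakens once the aromatic ring carried there by compound 1 and compound 3 is gone. An aromatic ring alone is not enough, though, since compound 2 carries one. Compound 2 and compound 4 are both limits, not numbers, so the step between them cannot be read: the limit of > 2000000 nM in this assay, at which 2 of the 4 values shown sit.

Going by these compounds, whether methoxy or a longer chain on that nitrogen would restore inhibition remains open. So does whether a cyclohexyl ring could stand in for the aromatic ring.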